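A few compounds are considered here, and "the series" means these few. Any claim that something is new, unique, unknown or untested is made for them only; others in the source may bear on it.

In a functional assay on A2780 cells (Homo sapiens) for antiproliferative activity, read by MTT assay, with a stated time of 48 h (on this read-out higher numbers stand for weaker inhibition and lower numbers for stronger inhibition), compound 1 (`COc1ccc(C(=O)c2ccc(OC)c3c2OC(C)(C)C=C3)c(NC(=O)CO)c1`) gives 100 nM, which places it at the strong end of the three measured compounds. Compound 2 (`COc1ccc(C(=O)c2ccc3c(c2)C=CC(C)(C)O3)c(NC(=O)CO)c1`) gives 130 nM, within the usual scatter of compound 1, so the two cannot be told apart. Compound 3 (`CNCC(=O)Nc1cc(OC)ccc1C(=O)c1ccc(OC)c2c1C=CC(C)(C)O2`) gives 1590 nM, a clearly higher number and so weaker inhibition.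

The unmeasured compound 4 (`COc1ccc(C(=O)c2ccc(OC)c3c2OC(C)(C)C=C3)c(NC(=O)CN(C)C)c1`) keeps the core of compound 1 and changes one group: dimethylamino in place of hydroxy on a saturated chain carbon bound to a carbonyl carbon. Within the data shown here, no measured pair isolates this single change. The nearest hint is compound 3 at 1590 nM, whose chain also carries an amine instead of hydroxy, though it differs from compound 1 elsewhere as well. A moderate move toward weaker inhibition in this assay is therefore expected, with considerable uncertainty. The expected step is a 6.0-fold higher number from compound 1 to compound 4 (0.78 log units; beyond the scatter). For compound 4 the estimated value is 600 nM, with an expected range of 150 nM to 2500 nM.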

Compound 4, half-maximal inhibitory concentration: 790 nM
The estimate for compound 4 lay 1.3-fold (0.12 log units) below the measured number; measured number inside the range.
By their numbers in this assay, from the lowest: compounds 1 and 2 (each within the scatter of the next); then compounds 4 and 3 (each within the scatter of the next).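

In this assay, among these compounds, putting dimethylamino in place of hydroxy on a saturated chain carbon bound to a carbonyl carbon gives a 7.9-fold higher number from compound 1 to compound 4 (0.90 log units; beyond the scatter), the first reading of this single change on an otherwise unchanged compound. So this position is not indifferent to what it carries: the step is beyond the usual scatter, and inhibition is weaker with dimethylamino. The swap removes the hydrogen-bond donor of hydroxy and also brings in a larger group, and no measurement shown separates these two differences or explains the step.

Still open, from the compounds shown here alone, is whether other groups at this place, such as an unsubstituted amine, a carboxylic acid or a longer chain ending in hydroxy, would keep the number low. Going by these compounds, it is also open whether the same swap would have a similar effect on the core of compound 2.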